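From 3-hydroxy-4-methoxyphenyl to 3,4-difluorophenyl on a shared core

A few compounds are considered here, and "the series" means these few. Any claim that something is new, unique, unknown or untested is made for them only; others in the source may bear on it.

Measured so far in a functional assay on SK-OV-3 cells (Homo sapiens) for cytotoxicity; a lower number here means a stronger inhibitor of growth, a higher number a weaker inhibitor of growth:
Compound 1 `COc1ccc(C2=C(c3ccc(SC)cc3)CC3CCCN3C2=O)cc1O`: > 100000 nM (a limit of the assay)
Compound 2 `COc1ccc(C2=C(c3ccc(SC)cc3)CC3CCCN3C2=O)cc1OC(=O)C1CCCN1C(=O)OC(C)(C)C`: 10000 nM
Compound 3 `COc1ccc(C2=C(c3ccc(SC)cc3)CC3CCCN3C2=O)cc1C`: 15000 nM

Going by the values given here, compound 1 has no number, only a limit, and it is the one compound of the three in that position: the limit of > 100000 nM in this assay, at which 1 of the 3 values shown sits. Compound 4 `CSc1ccc(C2=C(c3ccc(F)c(F)c3)C(=O)N3CCCC3C2)cc1`, not yet measured, keeps the core of compound 1 and its 4-(methylsulfanyl)phenyl group. On a double-bonded ring carbon it carries 3,4-difluorophenyl in place of 3-hydroxy-4-methoxyphenyl on a double-bonded ring carbon.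

Among the compounds with values here, one measured step touches this group: an at least 6.6-fold lower number from compound 1 to compound 3 (0.82 log units; beyond the scatter), beyond the scatter, with methyl in place of hydroxy and the methoxy kept. Compound 2 also has no free hydroxy, and it gives 10000 nM. Within the data shown here, compound 4 likewise has no free hydroxy, but it loses the methoxy as well, and no measured step covers that change. A step toward a lower number is therefore expected in this assay, of about the size seen with compound 3, and the estimate is an at least 5.0-fold lower number from compound 1 to compound 4 (0.69 log units; beyond the scatter). Compound 4 is estimated at 20000 nM, with an expected range of 5000 nM to 70000 nM.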

Compound 4, concentration for 50% growth inhibition: 100 nM
Compound 4: the middle estimate sits 200-fold (2.30 log units) above what was measured; measured number outside the range, below it.
By their numbers in this assay, from the lowest: compound 4; then compounds 2 and 3 (each within the scatter of the next). At a limit, above all of these: compound 1.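

In this assay, going by these compounds alone, the group on this double-bonded ring carbon proves able to move the growth inhibition much further than the earlier compounds showed: 3,4-difluorophenyl in place of 3-hydroxy-4-methoxyphenyl gives an at least 1000-fold lower number from compound 1 to compound 4 (3.00 log units; beyond the scatter). Losing the free hydroxy does not account for this on its own, since neither 4-methoxy-3-methylphenyl nor 3,4-difluorophenyl carries one, and that change still gives a 150-fold lower number from compound 3 to compound 4 (2.18 log units; beyond the scatter). Compound 1 has only a limit, so the first of these steps is a bound and not a measured size: the limit of > 100000 nM in this assay, at which 1 of the 4 values shown sits.

From the compounds shown here alone, what remains open is which part of the change does the work, since the two fluorines enter and the methoxy leaves together; a 4-fluorophenyl, a 3-fluoro-4-methoxyphenyl or an unsubstituted phenyl group on the same carbon would separate these contributions. Going by these compounds, it is also open whether 3,4-difluorophenyl would have the same effect with a group other than 4-(methylsulfanyl)phenyl on the neighbouring ring atom, such as 4-methoxyphenyl or 4-chlorophenyl.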